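The compounds below may be only part of what the source reports. "The series", "measured", "known", "first", "only" and "open" are said of these compounds alone.

Values in a functional assay on A549 cells (Homo sapiens) for cytotoxicity, with a stated time of 48 h; on this read-out lower numbers stand for stronger inhibition and higher numbers for weaker inhibition:
- compound 1 `Cc1ccc2c(=O)cc(/C=C/[S+](C)[O-])oc2c1`: 2000 nM
- compound 2 `C[S+]([O-])/C=C/c1cc(=O)c2ccccc2o1`: 1900 nM
- compound 3 `Cc1cccc2c(=O)cc(/C=C/[S+](C)[O-])oc12`: 1700 nM

The three values lie within the scatter of one another, so compound 2, at 1900 nM, cannot be ranked against its two neighbours. The next compound to consider is compound 4 `CCCCC(=O)Oc1ccc2oc(/C=C/[S+](C)[O-])cc(=O)c2c1`, which differs from compound 2 by one change: (butylcarbonyl)oxy in place of hydrogen on an aromatic carbon. In words, this is (butylcarbonyl)oxy in place of hydrogen on an aromatic carbon, para to a fused ring.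

Among the compounds with values here, two measured steps bear on this, a 1.1-fold lower number from compound 1 to compound 2 (0.02 log units; within the scatter) and a 1.1-fold lower number from compound 2 to compound 3 (0.05 log units; within the scatter). Within the data shown here, both exchange only methyl and hydrogen on an aromatic carbon, and the series so far responds to neither. Among the measured compounds shown here, no compound measured here carries a (butylcarbonyl)oxy group, so these steps offer only weak guidance for a substituent of this size. No step beyond the scatter is expected, and no direction can be assigned with confidence.

The expected change is a 1.1-fold lower number from compound 2 to compound 4 (0.02 log units; within the scatter). For compound 4 the estimated value is 1800 nM, with an expected range of 700 nM to 4500 nM.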

Compound 4, half-maximal inhibitory concentration: 2400 nM
The estimate for compound 4 lay 1.3-fold (0.12 log units) below the measured number; the measured number falls inside the stated range.
By their numbers in this assay, from the lowest: compounds 3, 2, 1 and 4 (each within the scatter of the next).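

In this assay, within the data shown here, (butylcarbonyl)oxy in place of hydrogen on the aromatic carbon para to a fused ring gives a 1.3-fold higher number from compound 2 to compound 4 (0.10 log units; within the scatter), the first reading at this place. The earlier steps shown here exchanged only methyl and hydrogen, so compound 4 adds that a much larger group, with a chain and a carbonyl, still leaves the number within the scatter of compound 2. No measurement shown here accounts for this result.

The compounds shown leave open whether any group at this carbon can move the number beyond the scatter. A hydroxyl, an amine or a longer acyl chain in the same place would test how far this lack of response extends, and whether it holds for groups unlike (butylcarbonyl)oxy.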